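Series notes: hydroxy to fluoro on the phenyl ring

The source may report more compounds than this note shows. Statements on the series, on what has been measured and on what is new or still open speak of the compounds shown alone.

compound 1 `CSc1nc(-c2cccc(O)c2)c2c(N)c(C(=O)NC(C)(C)C)sc2n1` — 63.9%
compound 2 `COc1cccc(-c2nc(SC)nc3sc(C(=O)NCc4ccccc4)c(N)c23)c1` — 7.8%
compound 3 `CCOC(=O)c1sc2nc(SC)nc(-c3cccc(OC)c3)c2c1N` — 4.2%

In a functional assay on HEK293 cells for agonist activity at lutropin-choriogonadotropic hormone receptor (Homo sapiens), read by cAMP accumulation (a higher number here means a larger maximal response, a lower number a smaller maximal response), compound 1 stands highest of the three; compound 2 lies below it beyond the scatter, and compound 3 lies further below, also beyond the scatter. Going by the values given here, the only measured single-point step, a number 3.6 percentage points lower from compound 2 to compound 3 (within the scatter), concerns the carbonyl substituent and lies within the scatter, so it offers no guidance on the phenyl ring. Compound 4 `CSc1nc(-c2cccc(F)c2)c2c(N)c(C(=O)NC(C)(C)C)sc2n1` differs from compound 1 by fluoro in place of hydroxy on an aromatic carbon. Among the compounds with values here, no measured step covers this change; compounds 2 and 3 differ from compound 1 in more than one group, so their low values do not isolate it. The expected step is therefore a number 18.9 percentage points lower from compound 1 to compound 4 (beyond the scatter), a moderate loss with wide uncertainty. Compound 4 is estimated at 45%, within 10% to 80%.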

Compound 4, largest response reached (reported as efficacy), in percent of the reference or control that the assay uses: 51.1%
For compound 4 the middle estimate is 6.1 percentage points below the measured one; measured number inside the range.
By their numbers in this assay, from the lowest: compounds 3 and 2 (each within the scatter of the next); then compound 4; then compound 1.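

In this assay, going by these compounds alone, the change from 3-hydroxyphenyl to 3-fluorophenyl gives a number 12.8 percentage points lower from compound 1 to compound 4 (beyond the scatter), the first reading of this position with the rest of the molecule held constant. The hydroxy group is therefore not essential for a substantial response, as compound 4 still reaches 51.1% without a hydrogen-bond donor or acceptor in that group. Nothing available explains the loss.

As far as these compounds go, whether an amino group or chloro in the same place would track compound 1 or compound 4 remains open. So does whether this step would carry over to the benzylamide of compound 2.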